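A few compounds are considered here, and "the series" means these few. Any claim that something is new, unique, unknown or untested is made for them only; others in the source may bear on it.

Measured so far:
- compound 1, `CCc1c(Cl)cc2[nH]c(=O)c(=O)[nH]c2c1N(CCO)S(C)(=O)=O`: 183 ng.h/mL
- compound 2, `CS(=O)(=O)N(CCCO)c1c(Cl)c(Cl)cc2[nH]c(=O)c(=O)[nH]c12`: 136 ng.h/mL
- compound 3, `Cc1cc2[nH]c(=O)c(=O)[nH]c2c(N(CCO)S(C)(=O)=O)c1Cl`: 791 ng.h/mL

All three share one core and carry a sulfonamide nitrogen with a short hydroxyalkyl chain; they differ in the substituents on the core and in the length of that chain. In an ADME assay on the whole organism (plasma, strain Sprague-Dawley) for pharmacokinetics, with Rattus norvegicus as the target, at a dose of 5 mg/kg by the oral route (on this read-out higher numbers stand for higher exposure at the dose given and lower numbers for lower exposure), compound 2 gives 136 ng.h/mL, the lowest of the three numbers. Compound 1 sits nearest, within the usual scatter, so the two cannot be told apart on this read-out. Compound 3 stands furthest, beyond the scatter, with a clearly higher number.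

The next compound, compound 4, `CC(O)CN(c1c(Cl)c(Cl)cc2[nH]c(=O)c(=O)[nH]c12)S(C)(=O)=O`, keeps everything of compound 2 and changes the chain in one place: 1-hydroxyethyl in place of 2-hydroxyethyl on a saturated chain carbon bound to a sulfonamide nitrogen. Within the data shown here, no step between two measured compounds mirrors this kind of change, so there is no direct guide to its size. With the same atoms merely joined differently, the expectation is a small step from compound 2, in no firm direction, and most likely within the scatter. The expected step of a 1.3-fold higher number from compound 2 to compound 4 (0.10 log units; within the scatter) reflects this. Compound 4 is therefore estimated at 170 ng.h/mL, with a plausible range from 60 ng.h/mL to 500 ng.h/mL.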

Compound 4, area under the concentration-time curve in the Rattus norvegicus assay: 680 ng.h/mL
The estimate for compound 4 lay 4.0-fold (0.60 log units) below the measured number, and the stated range ends below it.
By their numbers in the Rattus norvegicus assay, from the lowest: compounds 2 and 1 (each within the scatter of the next); then compounds 4 and 3 (each within the scatter of the next).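

Read as whole chains, this change turns 3-hydroxypropyl into 2-hydroxypropyl, and it shows that where the hydroxyl sits on this chain matters for exposure even though no atom is added or lost: in the Rattus norvegicus assay the change gives a 5.0-fold higher number from compound 2 to compound 4 (0.70 log units; beyond the scatter), the first step in this set that can be read for a single change. The same pair also gives a second read-out, and there the picture differs: in a physicochemical assay for solubility (on this read-out higher numbers stand for higher solubility and lower numbers for lower solubility), compound 2 gives 76 ug/mL and compound 4 gives 76 ug/mL, so the two numbers match while exposure does not. Nothing measured here explains why the chain change moves one read-out and leaves the other in place.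

The compounds shown leave open whether a 2-hydroxypropyl chain would produce a similar step on the cores of compound 1 and compound 3, which carry different substituents and a shorter chain. They also leave open what would happen at this position with a longer chain bearing a hydroxyl, or with an amine or a carboxylic acid in place of the hydroxyl.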